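A few compounds are considered here, and "the series" means these few. Any claim that something is new, unique, unknown or untested is made for them only; others in the source may bear on it.

Series notes. In a functional assay on UACC-62 cells (Homo sapiens) for antiproliferative activity, with a stated time of 48 h (a higher number here means that more compound is tolerated, a lower number that less compound is tolerated), compound 1 `Cc1cc(O)c(C2=NN(c3ccc(S(N)(=O)=O)cc3)C(c3ccccc3O)C2)cc1Cl` gives 40800 nM. Compound 2 `Cc1cc(O)c(C2=NN(c3ccc(S(N)(=O)=O)cc3)C(c3ccccc3Cl)C2)cc1Cl` gives 43400 nM in this assay, and compound 3 `COc1ccc(C2CC(c3cc(Cl)c(C)cc3O)=NN2c2ccc(S(N)(=O)=O)cc2)cc1OC` gives 43300 nM. All three measured steps stay inside the scatter: a 1.1-fold higher number from compound 1 to compound 2 (0.03 log units; within the scatter), a 1.1-fold higher number from compound 1 to compound 3 (0.03 log units; within the scatter) and a 1.0-fold lower number from compound 2 to compound 3 (0.00 log units; within the scatter). Compound 3 thus stands second highest of the three numbers, with compound 2 nearest and compound 1 furthest, both gaps inside the scatter, so no order among the three compounds can be read from this assay.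

Compound 4 `COc1ccc(C2CC(c3cc(Cl)c(C)cc3O)=NN2c2ccc(S(N)(=O)=O)cc2)c(OC)c1OC` differs from compound 3 by methoxy in place of hydrogen on an aromatic carbon. The two steps that bear on this change are the ones at the same saturated ring carbon, from compound 1 to compound 3 and from compound 2 to compound 3, where exchanging the whole aryl group moved the number by amounts inside the scatter. Adding one further methoxy to that aryl group is a smaller alteration than either of those exchanges, so no step beyond the scatter is expected in this assay. The step expected from this change is a 1.0-fold lower number from compound 3 to compound 4 (0.00 log units; within the scatter). Compound 4 is therefore estimated at 43000 nM, within a range from 24000 nM to 78000 nM.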

Compound 4, concentration lethal to 50% of the cells: 29200 nM
The estimate for compound 4 lay 1.5-fold (0.17 log units) above the measured number; measured number inside the range.
By their numbers in this assay, from the lowest: compounds 4, 1, 3 and 2 (each within the scatter of the next).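

In this assay, the aromatic carbon ortho to a large group and ortho to a methoxy group in compound 3 takes a further methoxy without leaving the scatter (a 1.5-fold lower number from compound 3 to compound 4 (0.17 log units; within the scatter)). Among these compounds, the exchanges of the whole aryl group for 2,3,4-trimethoxyphenyl, (a 1.5-fold lower number from compound 2 to compound 4 (0.17 log units; within the scatter)) and (a 1.4-fold lower number from compound 1 to compound 4 (0.15 log units; within the scatter)), also stay inside it, so a third methoxy on this aryl group, absent from the earlier compounds, still separates none of the four compounds in this assay. Beyond these numbers, nothing is available that bears on this change.

Among the compounds shown here, whether any group on this aryl ring can produce a step beyond the scatter remains open, since the 2-hydroxyphenyl, 2-chlorophenyl, 3,4-dimethoxyphenyl and 2,3,4-trimethoxyphenyl compounds give no such step, and an amine, a carboxylic acid or a longer chain such as butoxy at this carbon would test that further. The shown compounds also leave open whether changes elsewhere on the shared core would move the number, as all four keep that core unchanged.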